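Shortening the side chain and adding fluorines at the ether

The compounds below may be only part of what the source reports. "The series", "measured", "known", "first", "only" and "open" are said of these compounds alone.

Measured so far:
compound 1 `N[C@]1(C(=O)O)[C@H]2[C@@H](C[C@H]1OCCCc1ccccc1)[C@]2(F)C(=O)O` gives 9.83 nM
compound 2 `N[C@]1(C(=O)O)[C@H]2[C@@H](C[C@H]1OCc1ccc(-c3ccccc3)cc1)[C@]2(F)C(=O)O` gives 25.6 nM
compound 3 `N[C@]1(C(=O)O)[C@H]2[C@@H](C[C@H]1OCc1ccc(F)c(F)c1)[C@]2(F)C(=O)O` gives 2.27 nM

In an assay on CHO cells for binding affinity to metabotropic glutamate receptor 2 (Rattus norvegicus) (a higher number here means a weaker inhibitor, a lower number a stronger inhibitor), compound 1 stands second highest of the three numbers; compound 2 sits higher and compound 3 lower. Compound 4 `N[C@]1(C(=O)O)[C@H]2[C@@H](C[C@H]1OCc1c(F)cccc1F)[C@]2(F)C(=O)O` differs from compound 1 by 2,6-difluorophenyl in place of phenethyl on a saturated chain carbon bound to an oxygen on a saturated carbon. Among the compounds with values here, the one step that bears on this is a 4.3-fold lower number from compound 1 to compound 3 (0.64 log units; beyond the scatter), where a 3,4-difluorophenyl entered in place of the same phenethyl. Compound 4 carries its two fluorines in another pattern, so that step is only a rough guide, but it is the closest comparison available. A step in the same direction, somewhat smaller, is therefore expected: a 2.2-fold lower number from compound 1 to compound 4 (0.34 log units; beyond the scatter). Compound 4 is estimated at 4.5 nM, with a range from 1.5 nM to 14 nM.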

Compound 4, inhibition constant: 7.02 nM
Estimate against measurement, compound 4: 1.6-fold (0.19 log units) below; the measured number falls inside the stated range.
By their numbers in this assay, from the lowest: compound 3; then compounds 4 and 1 (each within the scatter of the next); then compound 2.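

The fluorine pattern on the ring matters at this position: with only that pattern altered, 2,6-difluorophenyl in place of 3,4-difluorophenyl gives a 3.1-fold higher number from compound 3 to compound 4 (0.49 log units; beyond the scatter). Exchanging phenethyl for a difluorophenyl therefore does not by itself guarantee a gain, since 2,6-difluorophenyl in place of phenethyl gives only a 1.4-fold lower number from compound 1 to compound 4 (0.15 log units; within the scatter), leaving that pair indistinguishable. No supporting measurement is available to explain the difference between the two fluorine patterns. Still open, as far as these compounds go, is whether a 2,4-difluorophenyl, a 4-fluorophenyl or a 4-chlorophenyl on the same chain carbon would track compound 3 or compound 4.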